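Methyl for hydrogen on the fused five-membered ring

The source may report more compounds than this note shows. Statements on the series, on what has been measured and on what is new or still open speak of the compounds shown alone.

Two compounds of this set have numbers in an in vitro functional assay on 1321-N1 cells for antagonist activity at transient receptor potential cation channel subfamily V member 1 (Homo sapiens), read by FLIPR and calcium flux; a higher number here means a more potent compound, by a factor of ten per unit of this negative logarithm, a lower number a less potent compound. Compound 2 `O=C(Nc1ccc2cccnc2c1)c1ccc(-c2ccccc2F)nc1` gives 8.7. Compound 3 `Cc1nc(-c2ccc(F)cc2)ccc1C(=O)Nc1ccc2cn[nH]c2c1` gives 7.5, the lower of the two numbers, with a gap to compound 2 that lies beyond the usual scatter. Compound 1 `Cc1nc(-c2ccc(F)cc2)ccc1C(=O)Nc1ccc2sc(N(C)C)nc2c1` reaches only a limit in this assay, < 5.8, and no number is available for it.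

Compound 4 `Cc1nc(-c2ccc(F)cc2)ccc1C(=O)Nc1ccc2c(C)n[nH]c2c1` differs from compound 3 by methyl in place of hydrogen on an aromatic carbon. For the measured compounds named here, no measured pair shows this change, so its effect is unknown. The step from compound 3 to compound 4 is expected to be a number 0.20 log units lower from compound 3 to compound 4 (within the scatter), a change not beyond the scatter in either direction. Compound 4 is therefore estimated at 7.3 in this assay, with a range from 6.5 to 8.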

Compound 4, negative logarithm of the antagonist equilibrium constant: 6.9
For compound 4 the middle estimate is 0.40 log units above the measured one, within the range that was stated.
By their numbers in this assay, from the lowest: compound 4; then compound 3; then compound 2. At a limit, below all of these: compound 1.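

In this assay, for the compounds shown here, methyl in place of hydrogen on this aromatic carbon, next to the ring nitrogen, gives a number 0.60 log units lower from compound 3 to compound 4 (beyond the scatter), the only measured pair for this change. The position therefore responds to this single added carbon, though one pair supports no wider pattern. Compound 4 still gives a number rather than a limit, so the step is read in full: the limit of < 5.8 in this assay, at which 1 of the 4 values shown sits.

The compounds shown leave open how an ethyl group, a longer chain or an amine at this carbon would read. They also leave open whether the same change would give a similar step at other positions on the fused ring.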